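The source may report more compounds than this note shows. Statements on the series, on what has been measured and on what is new or still open speak of the compounds shown alone.

Working notes on the series, read in a functional assay on MCF7 cells (Homo sapiens) for antiproliferative activity, read by sulforhodamine B assay, with a stated time of 72 h; on this read-out lower numbers stand for stronger inhibition and higher numbers for weaker inhibition. Compound 1 (`COc1ccc2nc(Cl)c(/C=C\c3ccc(C(F)(F)F)cc3)cc2c1`) gives 12400 nM. Compound 3 (`COc1ccc2nc(Cl)c(/C=C\c3ccc(F)cc3)cc2c1`) gives 8970 nM, and the two cannot be ranked, as the fluoro for trifluoromethyl swap is a 1.4-fold lower number from compound 1 to compound 3 (0.14 log units; within the scatter). Compound 2 (`COc1ccc2nc(Cl)c(/C=C/c3ccc(C(F)(F)F)cc3)cc2c1`) gives 47000 nM, the number furthest from compound 1, at a 3.8-fold higher number from compound 1 to compound 2 (0.58 log units; beyond the scatter). That gap comes with the fact that compounds 1 and 2 differ only in the configuration as drawn.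

Compound 4 (`COc1ccc2nc(Cl)c(/C=C\c3ccc(C(F)(F)F)cc3C(F)(F)F)cc2c1`) keeps the Z double bond of compound 1 and adds a second group to the same aromatic ring: trifluoromethyl in place of hydrogen on an aromatic carbon. This is trifluoromethyl in place of hydrogen on an aromatic carbon, ortho to a large group and meta to a trifluoromethyl group. The double-bond step does not apply here, as the configuration stays the same. Going by the values given here, the one measured change of a group on an aromatic carbon is a 1.4-fold lower number from compound 1 to compound 3 (0.14 log units; within the scatter), though it sits at a different place and is only a loose guide. On that basis, no step beyond the scatter is expected in this assay, with at most a slight drift towards a higher number. The expected step is a 1.2-fold higher number from compound 1 to compound 4 (0.08 log units; within the scatter). For compound 4 the estimated value is 15000 nM, with an expected range from 5000 nM to 45000 nM.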

Compound 4, half-maximal inhibitory concentration: > 50000 nM
Compound 4: a limit, no number (the forecaster's own chance of this, stated with the estimate: 10%); middle value at least 3.3-fold (0.52 log units) from the limit.
By their numbers in this assay, from the lowest: compounds 3 and 1 (each within the scatter of the next); then compound 2. At a limit, above all of these: compound 4.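

In this assay compound 4 gives > 50000 nM, which is a limit of the assay and not a number. Going by these compounds alone, with the Z double bond kept, trifluoromethyl in place of hydrogen on an aromatic carbon, ortho to a large group and meta to a trifluoromethyl group, gives an at least 4.0-fold higher number from compound 1 to compound 4 (0.60 log units; beyond the scatter), so a change on this aromatic ring can move the read-out beyond the scatter, which the fluoro for trifluoromethyl swap at the other place on the ring did not do, and the double-bond configuration is no longer the only change with a step of that kind. The step is bounded on one side only, so its full size cannot be read, and it rests on a single compound at the edge of the range: the limit of > 50000 nM in this assay, at which 1 of the 4 values shown sits.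

The compounds shown leave open whether this position responds to trifluoromethyl in particular or to any group placed there, and a methyl group, a hydroxyl group or an amine at the same aromatic carbon would separate those two readings. They also leave open how this position behaves with the E double bond of compound 2, where the same added trifluoromethyl would test whether the two changes act independently.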